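Swapping the aryl group on the chain in a vinyl sulfone series

The source may hold more compounds than are shown below. What is called first, only, known or untested is meant among the compounds shown, and "the series" means these compounds.

Measured compounds:
compound 1, `COc1ccccc1/C=C(\C(=O)c1ccc(Br)cc1)S(=O)(=O)c1ccc(C)cc1`: 1000 nM
compound 2, `COc1ccccc1/C=C(\C(=O)c1ccc(Br)cc1)S(=O)(=O)Cc1ccc(F)cc1`: 25000 nM
compound 3, `Cc1ccc(CS/C(=C/c2ccc(F)c(C)c2)C(=O)c2ccc(Cl)cc2)cc1`: 25000 nM

In a functional assay on DU-145 cells (Homo sapiens) for inhibition, read by trypan blue exclusion, with a stated time of 96 h (a higher number here means a weaker inhibitor of growth, a lower number a stronger inhibitor of growth), compound 2 gives 25000 nM. Going by the values given here, that number is level with the one for compound 3, and together the two stand highest of the three; compound 1 lies furthest from compound 2, by a 25-fold higher number from compound 1 to compound 2 (1.40 log units; beyond the scatter).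

Compound 4, `Cc1ccc(/C=C(\C(=O)c2ccc(Br)cc2)S(=O)(=O)Cc2ccc(F)cc2)s1`, differs from compound 2 at a single place: 5-methylthiophen-2-yl in place of 2-methoxyphenyl on a double-bonded chain carbon bound to a double-bonded chain carbon. Among the compounds with values here, the only measured step, a 25-fold higher number from compound 1 to compound 2 (1.40 log units; beyond the scatter), concerns the group on the sulfonyl sulfur, not the aryl group on the chain carbon, so no measured step bears on this change. The account therefore expects no step beyond the scatter, no change at the digits printed from compound 2 to compound 4 (within the scatter), and compound 4 is estimated at 25000 nM in this assay, within 8000 nM to 80000 nM.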

Compound 4, concentration for 50% growth inhibition: 1000 nM
Compound 4: the middle estimate sits 25-fold (1.40 log units) above what was measured; the measured number lies below the stated range.
By their numbers in this assay, from the lowest: compounds 1 and 4 (each within the scatter of the next); then compounds 2 and 3 (each within the scatter of the next).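

In this assay, the group on the double-bonded chain carbon proves to matter: 5-methylthiophen-2-yl in place of 2-methoxyphenyl gives a 25-fold lower number from compound 2 to compound 4 (1.40 log units; beyond the scatter) on the same 4-fluorobenzyl sulfonyl background. The earlier compounds had shown a step beyond the scatter only at the group on the sulfonyl sulfur, and this position is now a second such place. No measured evidence accounts for this step. From the compounds shown here alone, whether it would persist with 4-methylphenyl on the sulfonyl sulfur stays open, as does how an amine or a carboxylic acid on the aryl group at this chain carbon would read.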